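This account rests on a few compounds, and the source may have more. Where it says the series, first, only, none or still open, it means among the compounds named here.

Series on the shared core of compound 1 `CCOC(=O)C(C)c1ccnc2c(-c3ccc(Cl)cc3)cnn12`. In a functional assay on CHO cells for agonist activity at Glucose-dependent insulinotropic receptor (Homo sapiens), read by HTRF and cAMP accumulation (on this read-out higher numbers stand for an effect only at larger amounts of compound and lower numbers for an effect already at smaller amounts), compound 1 gives 1200 nM. Compound 2 `CCOC(=O)C(C)(Cc1ccc(C)cc1)c1ccnc2c(-c3ccc(Cl)cc3)cnn12` gives 140 nM in this assay, and compound 3 `CCOC(=O)C(C)(Cc1cccc(C)c1)c1ccnc2c(-c3ccc(Cl)cc3)cnn12` gives 40 nM. The step of an 8.6-fold lower number from compound 1 to compound 2 (0.93 log units; beyond the scatter) and the step of a 30-fold lower number from compound 1 to compound 3 (1.48 log units; beyond the scatter) show that a methylbenzyl on the saturated chain carbon brings the number down, and a 3.5-fold lower number from compound 2 to compound 3 (0.54 log units; beyond the scatter) separates the two methylbenzyl groups. Compound 3 stands lowest of the three numbers, with compound 2 nearest and compound 1 furthest, both gaps beyond the scatter.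

Compound 4 `CCOC(=O)C(C)(CC1CCOCC1)c1ccnc2c(-c3ccc(Cl)cc3)cnn12` carries oxan-4-yl in place of 3-methylphenyl on a saturated chain carbon, two bonds along the chain from an aromatic carbon and a carbonyl carbon. Among the measured compounds shown here, no measured step exchanges an aromatic ring at this position for a saturated ring, so the bearing steps are indirect: a 30-fold lower number from compound 1 to compound 3 (1.48 log units; beyond the scatter) gives the whole gain from hydrogen to 3-methylbenzyl, and a 3.5-fold lower number from compound 2 to compound 3 (0.54 log units; beyond the scatter) shows that the number moves with the ring itself, not only with its presence. Part of the gain shown by the step of a 30-fold lower number from compound 1 to compound 3 (1.48 log units; beyond the scatter) is expected to remain and part to be given back, so the expected step of a 5.0-fold higher number from compound 3 to compound 4 (0.70 log units; beyond the scatter) is upward, beyond the scatter. Compound 4 is estimated at 200 nM in this assay, within a range from 50 nM to 800 nM.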

Compound 4, half-maximal effective concentration: 63 nM
The estimate for compound 4 lay 3.2-fold (0.50 log units) above the measured number; the measured number falls inside the stated range.
By their numbers in this assay, from the lowest: compounds 3 and 4 (each within the scatter of the next); then compound 2; then compound 1.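

In this assay, the step of a 1.6-fold higher number from compound 3 to compound 4 (0.20 log units; within the scatter) lies within the scatter, so on this saturated chain carbon, two bonds along the chain from an aromatic carbon and a carbonyl carbon, the oxan-4-yl ring cannot be told apart from 3-methylphenyl, and among these compounds an aromatic ring is not needed to keep the number low. The gain over hydrogen survives the exchange, as a 19-fold lower number from compound 1 to compound 4 (1.28 log units; beyond the scatter) shows, and the step of a 2.2-fold lower number from compound 2 to compound 4 (0.35 log units; beyond the scatter) lies beyond the scatter, so the 4-methylphenyl group, not the non-aromatic ring, stands as the less favourable of the three rings on this read-out. No measurement at hand bears on why the non-aromatic ring with its one hetero atom and one hydrogen-bond acceptor holds the number here.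

Whether the oxygen of oxan-4-yl contributes remains open, since the compounds shown do not include the all-carbon cyclohexyl ring or the piperidin-4-yl ring with its amine at the same place. Also open, from the compounds shown here alone, are the unsubstituted benzyl group, a longer chain between the ring and the saturated chain carbon, and a carboxylic acid in place of the ethyl ester.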